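The source may hold more compounds than are shown below. What is called first, only, known or untested is meant among the compounds shown, and "the series" means these compounds.

Values in an in vitro ADME assay on microsomes from liver (Homo sapiens) for metabolic stability, using NADPH; a lower number here means slower removal, a higher number faster removal of the compound:
compound 1 (`CC(C)(CO)CNC(=O)c1cc2cc(C#N)ccc2n1Cc1cccc(OC(F)(F)F)c1`): 62 mL.min-1.g-1
compound 2 (`Cc1ccc(F)cc1Cn1c(C(=O)NCC2(CO)CCC2)cc2cc(C#N)ccc21`): 190 mL.min-1.g-1
compound 3 (`CC(C)(O)CCNC(=O)c1cc2cc(C#N)ccc2n1Cc1cccc(OC(F)(F)F)c1`): 9 mL.min-1.g-1

Compound 3 stands lowest of the three, beyond the scatter from both others. Compound 4 (`CC(O)CCNC(=O)c1cc2cc(C#N)ccc2n1Cc1cccc(OC(F)(F)F)c1`) changes 3-hydroxy-3-methylbutyl to 3-hydroxybutyl: hydrogen in place of methyl on a saturated chain carbon bound to an oxygen on a saturated carbon and two saturated chain carbons. Going by the values given here, one measured step bears on this chain (a 6.9-fold lower number from compound 1 to compound 3 (0.84 log units; beyond the scatter)). It is a different change, so it indicates a possible size, not a direction. Compound 2 differs in more than one place. With compound 3 at the low end, a rise smaller than that step is expected in this assay as a working guess. The expected change is a 1.8-fold higher number from compound 3 to compound 4 (0.25 log units; within the scatter) here. Compound 4 is estimated at 16 mL.min-1.g-1 (range 6 mL.min-1.g-1 to 45 mL.min-1.g-1).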

Compound 4, intrinsic clearance in microsomes: 113 mL.min-1.g-1
The estimate for compound 4 lay 7.1-fold (0.85 log units) below the measured number; the whole stated range lies below it.
By their numbers in this assay, from the lowest: compound 3; then compounds 1, 4 and 2 (each within the scatter of the next, the first and the last beyond it).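

Hydrogen in place of methyl on the saturated chain carbon bound to the oxygen gives a 13-fold higher number from compound 3 to compound 4 (1.10 log units; beyond the scatter) in this assay, so a single methyl at this position separates the lowest number so far from the rest. With a 1.8-fold higher number from compound 1 to compound 4 (0.26 log units; within the scatter), the 3-hydroxybutyl chain does not stand apart from the chain of compound 1, and the low number goes with 3-hydroxy-3-methylbutyl among the chains shown. No measurement given here accounts for this step.

Going by these compounds, whether ethyl at that carbon, or an amine in place of the hydroxyl, keeps the number low remains open. Also open, on these data alone, is whether 3-hydroxy-3-methylbutyl has the same effect with the other substituents of compound 2.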